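This account rests on a few compounds, and the source may have more. Where it says the series, first, only, none or still open, it means among the compounds named here.

Three compounds built on one shared core differ only in the group hanging from the end of a triple bond. Compound 1 `CNC(=O)[C@@]12C[C@@H]1[C@@H](n1cnc3c(NC)nc(C#Cc4ccc(F)cc4)nc31)[C@H](O)[C@@H]2O` carries a fluoro substituent on its aromatic ring, and in an assay on CHO cells for displacement of a labelled ligand from adenosine receptor A1 (Homo sapiens), read by scintillation counting, with a stated time of 60 min, tested at 10 uM (on this read-out higher numbers stand for more inhibition at the one concentration tested (going by the name of the read-out) and lower numbers for less inhibition), compound 1 gives 27%. Compound 2 `CNC(=O)[C@@]12C[C@@H]1[C@@H](n1cnc3c(NC)nc(C#Cc4ccc(Cl)cc4)nc31)[C@H](O)[C@@H]2O` carries chloro instead, and in this assay compound 2 gives 13%. Compound 3 `CNC(=O)[C@@]12C[C@@H]1[C@@H](n1cnc3c(NC)nc(C#Cc4ccc(CO)cc4)nc31)[C@H](O)[C@@H]2O` carries hydroxymethyl, and in this assay compound 3 gives 16%. On these three numbers compound 3 sits below compound 1, the step of a number 11 percentage points lower from compound 1 to compound 3 (beyond the scatter) lying beyond the scatter, while the step of a number 3 percentage points higher from compound 2 to compound 3 (within the scatter) lies within it, so compound 2 and compound 3 cannot be told apart.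

Compound 4 `CNC(=O)[C@@]12C[C@@H]1[C@@H](n1cnc3c(NC)nc(C#Cc4cnn(C)c4)nc31)[C@H](O)[C@@H]2O` makes a larger change than a swap of substituent: 1-methyl-1H-pyrazol-4-yl in place of 4-(hydroxymethyl)phenyl on a triple-bonded carbon. Going by the values given here, none of the measured steps exchanges the ring itself. The steps of a number 14 percentage points lower from compound 1 to compound 2 (beyond the scatter) and a number 11 percentage points lower from compound 1 to compound 3 (beyond the scatter) show that varying the group on the aromatic ring moved the read-out only modestly, and all three measured numbers lie in a low band. With nothing measured that bears directly on this change, compound 4 is expected to stay near compound 3, the step of a number 1 percentage points lower from compound 3 to compound 4 (within the scatter) expected to fall within the scatter. Compound 4 is estimated at 15%, with a range from 3% to 30%.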

Compound 4, a percentage reported as inhibition, at one concentration (the size of the read-out at that concentration, not a potency): 35%
Estimate against measurement, compound 4: 20 percentage points below, and the stated range ends below it.
By their numbers in this assay, from the lowest: compounds 2 and 3 (each within the scatter of the next); then compounds 1 and 4 (each within the scatter of the next).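

The earlier compounds shown here varied only the substituent on a six-membered aromatic ring of carbon only, while compound 4 exchanges the ring itself for 1-methyl-1H-pyrazol-4-yl, a five-membered aromatic ring with 2 hetero atoms, on the same triple-bonded carbon. In this assay, this exchange does not lower the reading; it gives a number 19 percentage points higher from compound 3 to compound 4 (beyond the scatter) and a number 22 percentage points higher from compound 2 to compound 4 (beyond the scatter), while the comparison with the fluoro compound gives a number 8 percentage points higher from compound 1 to compound 4 (within the scatter), so compound 1 and compound 4 cannot be told apart, and the 4-substituted phenyl ring is not needed to reach this level of inhibition. Nothing available explains why the five-membered ring reads as it does.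

From the compounds shown here alone, it remains open how an aminomethyl group or a carboxylic acid on the aromatic ring, or a longer chain in place of the methyl on the pyrazole, would read at this position. Each number is also a reading at a single concentration rather than a potency, so how these compounds would compare across a range of concentrations is unresolved.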